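This account rests on a few compounds, and the source may have more. Where it says the series, first, only, none or still open, it means among the compounds named here.

Going by the values given here, compound 1 `CC1CC/C(=N\Nc2ccccc2F)c2ncc(C(=O)O)c(=O)n21` holds the lowest number of the two measured so far: in a functional assay on the whole organism for inhibition, with Rattus norvegicus as the target (a lower number here means that less compound is needed, a higher number that more compound is needed for the effect), compound 1 gives 5 umol/kg. Compound 2 `C[C@H]1CC/C(=N\Nc2ccc(O)cc2)c2ncc(C(=O)O)c(=O)n21` gives 111 umol/kg in this assay, a gap to compound 1 well beyond the scatter. Compound 3 `Cc1ccc(N/N=C2\CCC(C)n3c2ncc(C(=O)O)c3=O)cc1` is not yet measured. It differs from compound 1 in one place: 4-methylphenyl in place of 2-fluorophenyl on an amine nitrogen. Among the compounds with values here, no step between measured compounds carries this change, so the direction rests on the two values alone. A rise is expected for compound 3 because compound 2, with a different aryl group, gives 111 umol/kg. The expected step is a 3.0-fold higher number from compound 1 to compound 3 (0.48 log units; beyond the scatter). Compound 3 is estimated at 15 umol/kg, with a range from 4 umol/kg to 60 umol/kg.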

Compound 3, dose for 50% inhibition: 1.3 umol/kg
Estimate against measurement, compound 3: 12-fold (1.06 log units) above; measured number outside the range, below it.
By their numbers in this assay, from the lowest: compound 3; then compound 1; then compound 2.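

On the amine nitrogen, the aryl group tolerates exchange: 4-methylphenyl in place of 2-fluorophenyl gives a 3.8-fold lower number from compound 1 to compound 3 (0.59 log units; beyond the scatter) in this assay. The fluorine of compound 1 is therefore not needed for a low dose here, and an aryl group of carbon only does at least as well. This single step is modest and gives no trend across aryl groups.

Going by these compounds, whether the lower number follows from gaining the methyl or losing the fluorine stays open, as does the outcome with a methoxy group or an amine on this phenyl ring. Nothing available bears on the reason for this step.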